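Fluorenone Carboxylic Acids: Truncating the Benzoyl Group

This account rests on a few compounds, and the source may have more. Where it says the series, first, only, none or still open, it means among the compounds named here.

Measured compounds:
compound 1 `O=C(O)c1ccc2ccc(C(=O)c3ccccc3)c-2cc1` — 32.9%
compound 2 `O=C(O)c1ccc2ccc(C(=O)c3ccc(C(F)(F)F)cc3)c-2cc1` — 1%

In an assay on cells for displacement of a labelled ligand from Orexin receptor type 2 (Homo sapiens), read by scintillation counting, with stated times of 10 min and 90 min, tested at 10 uM (a lower number here means less inhibition, a higher number more inhibition at the concentration tested (going by the name of the read-out)), compound 1 gives 32.9% and stands highest of the two numbers; the nearest is compound 2 with 1%, where a number 31.9 percentage points lower from compound 1 to compound 2 (beyond the scatter). Compound 3 `O=Cc1ccc2ccc(C(=O)O)ccc1-2` differs from compound 1 by hydrogen in place of phenyl on a carbonyl carbon. For the measured compounds named here, the one measured step concerns trifluoromethyl in place of hydrogen on the phenyl, not its removal, so it bears only loosely on this change; it does show that the phenyl substituent matters for the read-out. Compound 3 is expected to lose inhibition, a number 17.9 percentage points lower from compound 1 to compound 3 (beyond the scatter). The estimate for compound 3 is 15% (range 0% to 38%).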

Compound 3, a percentage reported as inhibition, at one concentration (the size of the read-out at that concentration, not a potency): 44.1%
The estimate for compound 3 lay 29.1 percentage points below the measured number, outside the stated range (above it).
By their numbers in this assay, from the lowest: compound 2; then compound 1; then compound 3.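

Hydrogen in place of phenyl on a carbonyl carbon brings a number 11.2 percentage points higher from compound 1 to compound 3 (beyond the scatter) in this assay and so the phenyl is not needed for inhibition at the concentration tested. Compound 1 and compound 2 showed only that a trifluoromethyl on that phenyl changes the number, whereas compound 3 shows that removing the whole ring does not lower it. Nothing available explains this rise. The compounds shown leave open how an amine, a methyl or a longer chain on this carbonyl carbon would compare with hydrogen. They also leave open whether a phenyl bearing another substituent would fall as far as compound 2 does.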